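Cyclopentyl for isopropyl on the amide nitrogen

The source may hold more compounds than are shown below. What is called first, only, known or untested is meant among the compounds shown, and "the series" means these compounds.

Compound 1 `CC(C)N1CCc2nc(C#Cc3ccccc3)ccc2C1=O` is the reference point of the series. In an assay on HEK293 cells for displacement of a labelled ligand from metabotropic glutamate receptor 5 (Homo sapiens), with a stated time of 2 h (a higher number here means a weaker inhibitor, a lower number a stronger inhibitor), compound 1 gives 1280 nM, the lowest of the two numbers in hand. Compound 2 `CC(C)N1CCc2nc(C#Cc3ccccc3Cl)ccc2C1=O` carries a chloro in place of hydrogen on an aromatic carbon; in this assay compound 2 gives 5680 nM, and the step of a 4.4-fold higher number from compound 1 to compound 2 (0.65 log units; beyond the scatter) is modest but beyond the scatter. Compound 3 `O=C1c2ccc(C#Cc3ccccc3)nc2CCN1C1CCCC1` has not yet been measured. It differs from compound 1 by cyclopentyl in place of isopropyl on an amide-type nitrogen in a ring. Going by the values given here, no measured step touches this part of the shared core: the only step available concerns the aromatic ring at the far end of the molecule and offers no guide to a change on the amide nitrogen. The step from compound 1 to compound 3 is therefore expected to be a 1.2-fold lower number from compound 1 to compound 3 (0.07 log units; within the scatter), none beyond the scatter. Compound 3 is expected to give 1100 nM in this assay, within a range from 400 nM to 3000 nM.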

Compound 3, inhibition constant: 890 nM
Beside the measured number, compound 3's estimate is 1.2-fold (0.09 log units) above it, and the stated range covers the measured number.
By their numbers in this assay, from the lowest: compounds 3 and 1 (each within the scatter of the next); then compound 2.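

Going by these compounds alone, the step on the amide-type nitrogen in a ring reads a 1.4-fold lower number from compound 1 to compound 3 (0.16 log units; within the scatter) in this assay and gives the first reading at this position. Cyclopentyl, with 5 heavy atoms and one five-membered non-aromatic ring of carbon only, takes the place of isopropyl, with 3 heavy atoms and no ring, and the result cannot be told apart from no change. This differs from the chloro step at the far aromatic ring, which reads a 4.4-fold higher number from compound 1 to compound 2 (0.65 log units; beyond the scatter) and so lies beyond the scatter, but nothing at hand speaks to what lies behind the flat result at the nitrogen.

Only isopropyl and cyclopentyl are shown on this nitrogen, so it remains open whether a methyl, a cyclohexyl, a phenyl or a chain ending in an amine or a carboxylic acid would move the number beyond the scatter. Also open, going by these compounds, is whether chloro on the aromatic ring would give a similar step on the cyclopentyl compound as on the isopropyl compound.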